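The compounds below may be only part of what the source reports. "The series", "measured", "known", "first", "only" and "open" are said of these compounds alone.

Compound 1 `COc1ccc(-c2cc(C(=O)/C=C/c3cc(OC)c(OC)c(OC)c3)nc3cc(-c4ccccc4)nn23)cc1OC`: 16700 nM
Compound 2 `COc1ccc(-c2cc(/C=C/C(=O)c3ccc(Cl)cc3)nc3cc(-c4ccccc4)nn23)cc1OC`: 17100 nM
Compound 3 `COc1cc(-c2cc(/C=C/C(=O)c3ccc(Cl)cc3)nc3cc(-c4ccccc4)nn23)cc(OC)c1OC`: 32500 nM

In a functional assay on MDA-MB-231 cells (Homo sapiens) for antiproliferative activity, read by MTT assay, with a stated time of 24 h (a lower number here means a stronger inhibitor, a higher number a weaker inhibitor), compound 2 gives 17100 nM; compound 1 lies nearest to it and compound 3 furthest, yet both gaps stay within the scatter. Compound 4 `COc1ccc(-c2cc(/C=C/C(=O)c3ccc(C)c(C)c3)nc3cc(-c4ccccc4)nn23)cc1OC` differs from compound 2 in one place: 3,4-dimethylphenyl in place of 4-chlorophenyl on a carbonyl carbon. Among the compounds with values here, the only measured step, a 1.9-fold higher number from compound 2 to compound 3 (0.28 log units; within the scatter), concerns a methoxy on a different aromatic ring and does not bear on this exchange; no measured pair swaps the group on the carbonyl carbon. With no anchor for the change, the step of a 1.2-fold higher number from compound 2 to compound 4 (0.07 log units; within the scatter) is expected to stay within the scatter. Compound 4 is therefore estimated at 20000 nM, with a range from 8000 nM to 50000 nM.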

Compound 4, half-maximal inhibitory concentration: 11500 nM
Compound 4: the middle estimate sits 1.7-fold (0.24 log units) above what was measured; low and high end bracket the measured number.
By their numbers in this assay, from the lowest: compounds 4, 1, 2 and 3 (each within the scatter of the next, the first and the last beyond it).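

In this assay, the exchange of 4-chlorophenyl for 3,4-dimethylphenyl on the carbonyl carbon gives a 1.5-fold lower number from compound 2 to compound 4 (0.17 log units; within the scatter). Within the data shown here, this is the only measured exchange at this position, and it shows that a ring carrying two methyl groups and no chlorine can take the place of the chlorine-bearing ring without a step beyond the scatter. Nothing available explains the size of this step. Still open, on these data alone, is whether an amine or a carboxylic acid on this ring would keep the number within the scatter of compound 2. As far as these compounds go, the same exchange on the core of compound 3 also remains open.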